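This account rests on a few compounds, and the source may have more. Where it says the series, first, only, none or still open, it means among the compounds named here.

Measured so far in a functional assay on the whole organism (blood) with Rattus norvegicus as the target, with stated times of 24 h and 1 h, at a dose of 5 mg/kg by the intraperitoneal route; on this read-out higher numbers stand for a stronger effect at the one dose given and lower numbers for a weaker effect:
compound 1 `CCCNC(=O)NS(=O)(=O)N1CCC(CCNC(=O)c2cc(Cl)ccc2OC)CC1` gives 11%
compound 2 `COc1ncccc1C(=O)NCCC1CCN(S(=O)(=O)NC(=O)NC2CCCCC2)CC1` gives 33%
compound 3 `COc1ccncc1C(=O)NCCC1CCN(S(=O)(=O)NC(=O)NC[C@@H]2C[C@@H]3C=C[C@@H]2C3)CC1` gives 14%

Compound 3 stands second highest of the three numbers. Compound 1, at 11%, lies within the scatter of compound 3, so the two cannot be told apart. Compound 2, at 33%, lies beyond the scatter and is the higher of that pair.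

Compound 4 `O=C(NC[C@@H]1C[C@@H]2C=C[C@@H]1C2)NS(=O)(=O)N1CCC(CCNC(=O)c2cccc3c2OCCO3)CC1` has not been measured. It differs from compound 3 in one place: 2,3-dihydro-1,4-benzodioxin-5-yl in place of 4-methoxypyridin-3-yl on a carbonyl carbon. Among the compounds with values here, no pair of measured compounds isolates this change, so there is no measured step to lean on. The expectation is a step from compound 3 to compound 4 of a number 4 percentage points higher from compound 3 to compound 4 (within the scatter), in no direction beyond the scatter. Compound 4 is therefore estimated at 18%, with a range from 5% to 35%.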

Compound 4, a percentage reported as activity, at one dose (the size of the read-out at that dose, not a potency): 11%
For compound 4 the middle estimate is 7 percentage points above the measured one; low and high end bracket the measured number.
By their numbers in this assay, from the lowest: compounds 1, 4 and 3 (each within the scatter of the next); then compound 2.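

Putting 2,3-dihydro-1,4-benzodioxin-5-yl in place of 4-methoxypyridin-3-yl on a carbonyl carbon gives a number 3 percentage points lower from compound 3 to compound 4 (within the scatter) in this assay. Within the data shown here, this is the first single-place comparison, and at the one dose given the two compounds cannot be told apart, although the entering group has a second ring and no ring nitrogen. Nothing available explains this result. Going by these compounds, it remains open whether a different group at this place, such as an unsubstituted phenyl or a benzoic acid ring, would give a step beyond the scatter.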